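The source may hold more compounds than are shown below. What is called first, only, known or untested is meant among the compounds shown, and "the series" means these compounds.

Compound 1 `COc1ccccc1Oc1c(N)nc(-c2cccc(I)c2)nc1Cl` gives 27600 nM
Compound 2 `COc1ccccc1Oc1c(N)nc(-c2cccc(Cl)c2)nc1OCCO` gives 5010 nM

In a functional assay on B16 cells (Mus musculus) for cytotoxicity, read by CCK-8 assay, with a stated time of 24 h (on this read-out lower numbers stand for stronger inhibition and higher numbers for weaker inhibition), compound 2 holds the lower of the two numbers, and its gap to compound 1 lies beyond the scatter. Among the measured compounds shown here, no two measured compounds differ in one place only, so no single change has a measured step yet. Compound 3 `COc1ccccc1Oc1c(N)nc(-c2cccc(I)c2)nc1OCCO` differs from compound 2 by one exchange iodo in place of chloro on an aromatic carbon with iodo in place of chloro on an aromatic carbon, meta to a large group. With nothing measured for this exchange, the expectation starts from compound 2 at 5010 nM and foresees no step beyond the scatter in this assay in either direction. The expected step is small (a 1.1-fold lower number from compound 2 to compound 3 (0.05 log units; within the scatter)). For compound 3 the estimated value is 4500 nM with an expected range of roughly the same order (1800 nM to 11500 nM).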

Compound 3, half-maximal inhibitory concentration: 20300 nM
Beside the measured number, compound 3's estimate is 4.5-fold (0.65 log units) below it; measured number above the stated range.
By their numbers in this assay, from the lowest: compound 2; then compounds 3 and 1 (each within the scatter of the next).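

In this assay, among the compounds shown here, the exchange of 3-chlorophenyl for 3-iodophenyl with the 2-hydroxyethoxy group held constant gives a 4.1-fold higher number from compound 2 to compound 3 (0.61 log units; beyond the scatter) and is the first measured step at this place, so the halogen on this aromatic carbon is not interchangeable here. With the 3-iodophenyl group held constant, replacing the chloro by 2-hydroxyethoxy gives a 1.4-fold lower number from compound 1 to compound 3 (0.13 log units; within the scatter) and so shows no resolved effect in this iodo setting. Nothing measured on these compounds accounts for the halogen step.

For the compounds shown here, whether the 2-hydroxyethoxy exchange reads the same with 3-chlorophenyl remains open, as that step has no measured pair. Also open, from the compounds shown here alone, is how bromo or fluoro at this place, or an amine or a longer chain in place of 2-hydroxyethoxy, would read.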